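Cyano to iodo on the sulfonyl ring of compound 1

The source may hold more compounds than are shown below. What is called first, only, known or untested is meant among the compounds shown, and "the series" means these compounds.

Among the compounds with values here, compound 1 `COc1ccc(NS(=O)(=O)c2cccc(C#N)c2)cc1N1CCN(C)CC1` is the weaker of the two measured members: in an assay on HeLa cells for binding affinity to 5-hydroxytryptamine receptor 6 (Homo sapiens) (on this read-out lower numbers stand for stronger inhibition and higher numbers for weaker inhibition), compound 1 gives 63.1 nM, the highest number in the set. Within the data shown here, the only other measured member, compound 2 `COc1ccc(NS(=O)(=O)c2c(F)c(Br)cc(F)c2Br)cc1N1CCN(C)CC1`, gives 3.16 nM in this assay, a gap well beyond the scatter; no single-point step between the two is available.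

Compound 3 `COc1ccc(NS(=O)(=O)c2cccc(I)c2)cc1N1CCN(C)CC1` differs from compound 1 by iodo in place of cyano on an aromatic carbon. Nothing measured bears directly on this exchange, so the size of the step is uncertain. The expectation is a modest gain, a step from compound 1 to compound 3 of about a 3.2-fold lower number from compound 1 to compound 3 (0.50 log units; beyond the scatter), resting only on the low number of the halogenated compound 2 at 3.16 nM as loose support. Compound 3 is therefore estimated at 20 nM in this assay, with a range from 5 nM to 80 nM.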

Compound 3, inhibition constant: 0.794 nM
Compound 3: middle estimate off by 25-fold (1.40 log units), on the high side; the whole stated range lies above it.
By their numbers in this assay, from the lowest: compound 3; then compound 2; then compound 1.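

Within the data shown here, the exchange of 3-cyanophenyl for 3-iodophenyl gives a 79-fold lower number from compound 1 to compound 3 (1.90 log units; beyond the scatter) in this assay, and this is the first step that can be read at a single place. It shows that one substituent on this aromatic carbon, meta to a large group, can alone move the number far beyond the scatter, with the rest of the core of compound 1 unchanged. Among these compounds, the change removes the cyano group's hydrogen-bond acceptor and replaces its two heavy atoms with one iodine, but no measurement ties the step to either difference or to any other.

From the compounds shown here alone, it remains open whether the step is particular to iodo. Bromo, chloro, methoxy or an amine on the same aromatic carbon would show how far it extends.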